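The source may report more compounds than this note shows. Statements on the series, on what has been measured and on what is new or still open speak of the compounds shown alone.

Working notes on the series. For the measured compounds named here, compound 1 (`COc1ccccc1/C=C(\C(=O)c1ccc(Br)cc1)S(=O)(=O)c1ccc(C)cc1`) is the anchor: in a functional assay on DU-145 cells (Homo sapiens) for inhibition, read by trypan blue exclusion, with a stated time of 96 h (on this read-out lower numbers stand for stronger inhibition of growth and higher numbers for weaker inhibition of growth), compound 1 gives 1000 nM, the only true number so far. Compound 2 (`Cc1ccc(S(=O)(=O)/C(=C/c2c(O)cc(O)cc2O)C(=O)c2ccc(Br)cc2)cc1`) reads > 100000 nM, which is a limit of the assay and not a number.

Compound 3 (`Cc1ccc(S(=O)(=O)/C(=C/c2ccccc2OCc2ccccc2)C(=O)c2ccc(Br)cc2)cc1`) keeps the core of compound 1 and changes one place, methoxy to benzyloxy: phenyl in place of hydrogen on a saturated chain carbon bound to an oxygen on an aromatic ring.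

Going by the values given here, one measured step touches the same aryl group, an at least 100-fold higher number from compound 1 to compound 2 (2.00 log units; beyond the scatter), which is large and beyond the scatter. That step swaps 2-methoxyphenyl for 2,4,6-trihydroxyphenyl, a different change, so it shows that this group can move the number but gives no size to carry over. A far smaller step is therefore expected in this assay, towards a somewhat higher number, with weaker inhibition of growth the likelier direction and no change beyond the scatter still possible.

The estimated step is a 2.0-fold higher number from compound 1 to compound 3 (0.30 log units; within the scatter). For compound 3 the expected value is 2000 nM, with an estimated range of 300 nM to 15000 nM.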

Compound 3, concentration for 50% growth inhibition: 1000 nM
Beside the measured number, compound 3's estimate is 2.0-fold (0.30 log units) above it; low and high end bracket the measured number.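

In this assay, the methoxy to benzyloxy change gives no change at the digits printed from compound 1 to compound 3 (within the scatter), so phenyl in place of hydrogen on a saturated chain carbon bound to an oxygen on an aromatic ring leaves the number where it was. For the compounds shown here, the only earlier step at this aryl group, an at least 100-fold higher number from compound 1 to compound 2 (2.00 log units; beyond the scatter), showed that the group can move the number, whereas the new step shows that it does not do so for every change and that an added phenyl of 6 heavy atoms is accommodated here without loss of growth inhibition. The two steps are different changes, so this contrast rests on compound 1, compound 2 and compound 3 alone and gives no rule for the aryl group as a whole.

Going by these compounds, compound 2 stands at a limit of the assay and not at a number, so the full size of its step stays unknown: the limit of > 100000 nM in this assay, at which 1 of the 3 values shown sits. Still open is whether a free hydroxyl in place of the methoxy group, a longer chain such as propyl, or an amine at the end of such a chain would keep the number within the scatter of compound 1.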